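The compounds below may be only part of what the source reports. "The series", "measured", "known", "first", "only" and "open" are said of these compounds alone.

Measured compounds in an assay on CHO cells for displacement of a labelled ligand from 5-hydroxytryptamine receptor 1B (Homo sapiens); on this read-out lower numbers stand for stronger inhibition and higher numbers for weaker inhibition:

- compound 1 `O=S(=O)(NCC1CCN(CCCc2c[nH]c3ccc(-n4cnnc4)cc23)CC1)c1ccccc1` gives 60 nM
- compound 2 `CN(Cc1cccs1)C1CCN(CCCc2c[nH]c3ccc(-n4cnnc4)cc23)CC1` gives 140 nM
- compound 3 `c1cc(CNC2CCN(CCCc3c[nH]c4ccc(-n5cnnc5)cc34)CC2)co1` gives 78 nM

Compound 2 carries the highest number of the three. Toward compound 1 the gap is a 2.3-fold higher number from compound 1 to compound 2 (0.37 log units; beyond the scatter), beyond the scatter; toward compound 3 the gap is a 1.8-fold lower number from compound 2 to compound 3 (0.25 log units; within the scatter), within the scatter, so compound 2 and compound 3 are not separated by this assay, and only compound 1 stands clearly lower.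

Compound 4 `CC(=O)Nc1ccc(CN(C)C2CCN(CCCc3c[nH]c4ccc(-n5cnnc5)cc34)CC2)cc1` keeps the shared core of compound 2 and the methylamino-substituted piperidine; the change is 4-acetamidophenyl in place of thiophen-2-yl on a saturated chain carbon bound to an amine nitrogen. Among the compounds with values here, no measured step alters the aryl alone while the amine is kept. The steps that touch this region exchange the whole substituent on the piperidine carbon: a 2.3-fold higher number from compound 1 to compound 2 (0.37 log units; beyond the scatter) and a 1.8-fold lower number from compound 2 to compound 3 (0.25 log units; within the scatter). Both are modest, and they show that quite different groups at this position give numbers close to one another. The expectation for compound 4 is therefore a number near compound 2, with at most a small shift and none clearly beyond the scatter; the direction cannot be read from the three compounds, with a slight lean toward the lower numbers of compound 1 and compound 3.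

Compound 4 is estimated at 110 nM in this assay, with a range from 45 nM to 280 nM. This estimate corresponds to an expected step of a 1.3-fold lower number from compound 2 to compound 4 (0.10 log units; within the scatter).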

Compound 4, half-maximal inhibitory concentration: 100 nM
Estimate against measurement, compound 4: 1.1-fold (0.04 log units) above; measured number inside the range.
By their numbers in this assay, from the lowest: compounds 1, 3, 4 and 2 (each within the scatter of the next, the first and the last beyond it).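

In this assay, within the data shown here, a 1.4-fold lower number from compound 2 to compound 4 (0.15 log units; within the scatter) is the first step that alters the aryl group alone while the rest of compound 2 is kept, and it lies within the scatter. On a saturated chain carbon bound to an amine nitrogen, this assay therefore does not separate thiophen-2-yl from 4-acetamidophenyl, even though the entering group brings more heavy atoms, a six-membered aromatic ring of carbon only and a hydrogen-bond donor that thiophen-2-yl lacks. Nothing available accounts for this tolerance or says whether the acetamido group contributes to the number of compound 4.

Whether the same tolerance holds for a carboxylic acid or a primary amine in place of the acetamido group remains open, since the only substituted aryl group shown is 4-acetamidophenyl. Also open is what the methyl on the amine nitrogen contributes, since the compounds shown offer no pair that differs in that methyl alone, and a matched partner of compound 4 with hydrogen on that nitrogen would settle it.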